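Anilino for Isobutyl on the Imine Nitrogen

The compounds below may be only part of what the source reports. "The series", "measured", "known", "first", "only" and "open" are said of these compounds alone.

For the measured compounds named here, compound 1 `C/C(=N\CC(C)C)c1c(O)c2ccccc2oc1=O` is the only compound here with a numerical reading: in an assay on isolated protein for inhibition of myosin-2 (Bos taurus), read by spectrophotometry, with a stated time of 24 min (on this read-out higher numbers stand for weaker inhibition and lower numbers for stronger inhibition), compound 1 gives 34000 nM. Going by the values given here, compound 2 `CCC(C)/N=C(\C)c1c(O)c2ccccc2[nH]c1=O` differs from compound 1 both in its core and in the group on the double-bonded nitrogen, so no single-place step connects the two. In this assay compound 2 gives >= 100000 nM, which is the limit of >= 100000 nM in this assay, at which 1 of the 2 values shown sits, a limit of the assay rather than a number.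

Compound 3 `C/C(=N\Nc1ccccc1)c1c(O)c2ccccc2oc1=O` is not yet measured. It arises from compound 1 by anilino in place of isobutyl on a double-bonded nitrogen. No measured step of this kind exists among the compounds shown, so the expectation rests on compound 1 alone. The step of a 1.7-fold lower number from compound 1 to compound 3 (0.23 log units; within the scatter) is expected to be modest, within or barely beyond the scatter, leaning toward stronger inhibition. Compound 3 is therefore estimated at 20000 nM, with a range from 5000 nM to 80000 nM.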

Compound 3, half-maximal inhibitory concentration: 27000 nM
Compound 3: middle estimate off by 1.4-fold (0.13 log units), on the low side, and the stated range covers the measured number.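

With anilino in place of isobutyl on a double-bonded nitrogen, this assay shows a 1.3-fold lower number from compound 1 to compound 3 (0.10 log units; within the scatter). For the compounds shown here, this is the first reading of a single change at this position: a group with a six-membered aromatic ring, a hydrogen-bond donor and a hydrogen-bond acceptor takes the place of a ringless isobutyl chain, and the two readings stay within the scatter of each other. Nothing measured here offers a reason for this result.

On these data alone, whether a benzyl group, a longer chain, an amine or a carboxylic acid on this nitrogen would also stay within the scatter remains open, as does the effect of a methoxy group on the aromatic ring of anilino. Also open, as far as these compounds go, is how the same change would read on the core of compound 2, whose only reading is a limit.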